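Inverting one stereocentre of compound 3

A few compounds are considered here, and "the series" means these few. Any claim that something is new, unique, unknown or untested is made for them only; others in the source may bear on it.

- Compound 1 (`Cc1cc(=O)c2c(O)cc(OCC3CO3)cc2o1`): 13600 nM
- Compound 2 (`Cc1cc(=O)c2c(O)cc(OC[C@@H]3CO3)cc2o1`): 36200 nM
- Compound 3 (`Cc1cc(=O)c2c(OC[C@@H]3CO3)cc(OC[C@@H]3CO3)cc2o1`): 46100 nM

In a functional assay on MCF7 cells (Homo sapiens) for antiproliferative activity, with a stated time of 48 h (a higher number here means a weaker inhibitor, a lower number a stronger inhibitor), compound 3 sits level with compound 2 (a 1.3-fold higher number from compound 2 to compound 3 (0.10 log units; within the scatter)) and has a higher number than compound 1, beyond the scatter. Compound 4 (`Cc1cc(=O)c2c(OC[C@H]3CO3)cc(OC[C@@H]3CO3)cc2o1`) is related to compound 3 by one change (the two compounds have the same atoms and bonds and differ only in configuration as drawn: 1 of 2 stereo elements differ; a stereocentre at a saturated ring carbon is drawn S in compound 3 and R in compound 4). For the measured compounds named here, the only measured step in configuration (a 2.7-fold higher number from compound 1 to compound 2 (0.43 log units; beyond the scatter)) is modest and traces to the fact that one of compounds 1 and 2 is drawn with a defined configuration and the other without, at the place where they differ so it does not compare S with R directly. Adding the (oxiran-2-yl)methyl group to compound 2 gave no shift beyond the scatter. Only a small step within the scatter, towards a lower number, is therefore expected (a 1.3-fold lower number from compound 3 to compound 4 (0.11 log units; within the scatter)). For compound 4 the expected value is 36000 nM (range 16000 nM to 75000 nM).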

Compound 4, half-maximal inhibitory concentration: 1880 nM
Compound 4: the middle estimate sits 19-fold (1.28 log units) above what was measured; the whole stated range lies above it.
By their numbers in this assay, from the lowest: compound 4; then compound 1; then compounds 2 and 3 (each within the scatter of the next).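

In this assay the (oxiran-2-yl)methyl group added to compound 2 has an effect that depends on its configuration: drawn R it gives a large step (a 19-fold lower number from compound 2 to compound 4 (1.28 log units; beyond the scatter)), while drawn S the step stays within the scatter (a 1.3-fold higher number from compound 2 to compound 3 (0.10 log units; within the scatter)). For the compounds shown here, this is the first direct comparison of S with R at this saturated ring carbon, and the large step (a 25-fold lower number from compound 3 to compound 4 (1.39 log units; beyond the scatter)) can be assigned to that stereocentre alone: the fact that compounds 3 and 4 differ only in the configuration as drawn.

Open, going by these compounds, is whether inverting the other stereocentre has a comparable effect. Also open, on these data alone, is whether an amine or a longer chain on this oxygen would match compound 4.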